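The source may hold more compounds than are shown below. What is called first, only, known or untested is meant among the compounds shown, and "the series" means these compounds.

Compound 1 `COc1ccc2c(=O)c(/C=C/C(=O)Nc3cccc(Cl)c3)coc2c1`: in a functional assay (QGY7701 cells, Homo sapiens) for inhibition, read by MTT assay, with a stated time of 48 h (a lower number here means a stronger inhibitor, a higher number a weaker inhibitor), compound 1 reaches only a limit of the assay, > 100000 nM.
Compound 2 `COc1ccc2c(=O)c(/C=C/C(=O)Nc3cc(C)ccc3C)coc2c1`: in this assay compound 2 also sits at a limit, > 100000 nM.
Compound 3 `COc1ccc(CNC(=O)/C=C/c2coc3cc(OC)ccc3c2=O)cc1`: in this assay compound 3 gives 15700 nM.

Within the data shown here, compound 3 thus carries the only true number in the set; the other two values are limits. Compound 4 `COc1ccc2c(=O)c(/C=C/C(=O)NCc3ccc(C)cc3)coc2c1` differs from compound 3 by methyl in place of methoxy on an aromatic carbon. The measured steps, an at least 6.3-fold lower number from compound 1 to compound 3 (0.80 log units; beyond the scatter) and an at least 6.3-fold lower number from compound 2 to compound 3 (0.80 log units; beyond the scatter), both start from values at the limit of > 100000 nM in this assay, at which 2 of the 3 values shown sit, and concern a benzyl group replacing a substituted phenyl on the amide nitrogen; neither compares methyl with methoxy on that benzyl group. No shown step therefore bears directly on this change, and compound 4 is expected to stay within the scatter of compound 3, a 1.0-fold higher number from compound 3 to compound 4 (0.01 log units; within the scatter). Compound 4 is estimated at 16000 nM, between 5000 nM and 50000 nM.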

Compound 4, half-maximal inhibitory concentration: 10200 nM
Beside the measured number, compound 4's estimate is 1.6-fold (0.20 log units) above it, within the range that was stated.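

With methyl in place of methoxy on the benzyl group, para to a large group, this assay shows a 1.5-fold lower number from compound 3 to compound 4 (0.19 log units; within the scatter), so this position accepts either group without a change beyond the scatter. A second benzyl amide now stands apart from the phenyl amides: an at least 9.8-fold lower number from compound 2 to compound 4 (0.99 log units; beyond the scatter) and an at least 9.8-fold lower number from compound 1 to compound 4 (0.99 log units; beyond the scatter) are seen, and compounds 3 and 4 both fit this pattern. As far as these compounds go, the true size of these two steps stays unknown, as each starts from a limit: the limit of > 100000 nM in this assay, at which 2 of the 4 values shown sit. From the compounds shown here alone, whether a hydroxyl, an amine or a carboxylic acid at this position would move the number beyond the scatter remains open.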